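The compounds below may be only part of what the source reports. "The series", "measured", "known", "first", "only" and "open" are said of these compounds alone.

Measured compounds and their results:

Compound 1, `COc1ccc(C(=O)c2cc(OC)c(OC)c(OC)c2)cc1NC(=O)/C=C/c1ccc(C(F)(F)F)cc1`, in a functional assay on COLO 205 cells (Homo sapiens) for cytotoxicity, read by MTT assay, with a stated time of 72 h (a higher number here means a weaker inhibitor, a lower number a stronger inhibitor), compound 1 gives 2600 nM.
Compound 2, `COc1ccc(/C=C/C(=O)Nc2cc(C(=O)c3cc(OC)c(OC)c(OC)c3)cc(OC)c2OC)cc1N`, in this assay compound 2 gives 10100 nM.
Compound 3, `C#CCOc1cccc(/C=C/C(=O)Nc2cc(C(=O)c3cc(OC)c(OC)c(OC)c3)cc(OC)c2OC)c1`, in this assay compound 3 gives 11200 nM.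

Compound 3 stands at the highest number of the three, the weakest reading here. Its nearest neighbour is compound 2, and the difference between them, a 1.1-fold higher number from compound 2 to compound 3 (0.04 log units; within the scatter), is too small to count. Compound 1, by contrast, sits a good way lower, beyond the scatter.

Compound 4, `COc1cc(C(=O)c2cc(OC)c(OC)c(OC)c2)cc(NC(=O)/C=C/c2ccc(C(F)(F)F)cc2)c1OC`, has not yet been measured in this assay. It arises from compound 3 by one change: 4-(trifluoromethyl)phenyl in place of 3-(propargyloxy)phenyl on a double-bonded chain carbon bound to a double-bonded chain carbon. Going by the values given here, no measured pair carries exactly this swap. Among the compounds with values here, what the numbers show is that compound 1, which bears the same 4-(trifluoromethyl)phenyl group on a different partner, gives a lower number than compound 3, while the one measured step, from compound 2 to compound 3, changed the aryl group without moving the number beyond the scatter. On balance a modest drop is expected, so compound 4 is estimated at 5000 nM, in the range 2000 nM to 13000 nM, a step of a 2.2-fold lower number from compound 3 to compound 4 (0.35 log units; beyond the scatter).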

Compound 4, half-maximal inhibitory concentration: 2500 nM
Compound 4: middle estimate off by 2.0-fold (0.30 log units), on the high side; low and high end bracket the measured number.
By their numbers in this assay, from the lowest: compounds 4 and 1 (each within the scatter of the next); then compounds 2 and 3 (each within the scatter of the next).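

In this assay, the group on this double-bonded chain carbon can clearly shift the reading: 4-(trifluoromethyl)phenyl gives a 4.5-fold lower number from compound 3 to compound 4 (0.65 log units; beyond the scatter) and a 4.0-fold lower number from compound 2 to compound 4 (0.61 log units; beyond the scatter), whereas the earlier swap of one aryl group for another stayed within the scatter. With 4-(trifluoromethyl)phenyl in place, methoxy in place of hydrogen on an aromatic carbon makes no readable difference, giving a 1.0-fold lower number from compound 1 to compound 4 (0.02 log units; within the scatter). No measurement here explains why this aryl group gives the lower number.

The compounds shown leave open whether the trifluoromethyl group itself matters, or whether a simple 4-chlorophenyl or 4-cyanophenyl group on the same chain carbon would read alike. Also open, as far as these compounds go, is whether that methoxy would remain without effect alongside 3-(propargyloxy)phenyl or 3-amino-4-methoxyphenyl.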